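The compounds below may be only part of what the source reports. "The series", "measured", "known", "first", "only" and "open" are said of these compounds alone.

Among the compounds with values here, in a physicochemical assay for lipophilicity, using the shake flask method (on this read-out higher numbers stand for higher lipophilicity and lower numbers for lower lipophilicity), compound 1 (`C[C@H](Oc1cc2cc(C#N)ccc2nc1N)c1cc(F)ccc1-n1cccn1`) gives 3.8, the lower of the two numbers so far, while compound 2 (`C[C@H](Oc1cc2cc(C#N)ccc2nc1N)c1cc(F)c(F)cc1-n1cccn1`) gives 4.3. Compound 3 (`C[C@H](Oc1cc2ccccc2nc1N)c1cc(F)ccc1-n1cccn1`) departs from compound 1 by one change: hydrogen in place of cyano on an aromatic carbon. Within the data shown here, no measured pair covers this change. Among the measured compounds shown here, the only measured step, a number 0.50 log units higher from compound 1 to compound 2 (beyond the scatter), involves a different group, so it offers a rough scale and no direct precedent. A modest upward move in this assay is expected, of similar size to that step. The expected step is a number 0.40 log units higher from compound 1 to compound 3 (beyond the scatter). Compound 3 is estimated at 4.2, with an expected range from 3.8 to 4.7.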

Compound 3, distribution coefficient: 4
The estimate for compound 3 lay 0.20 log units above the measured number; measured number inside the range.
By their numbers in this assay, from the lowest: compounds 1, 3 and 2 (each within the scatter of the next, the first and the last beyond it).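

Hydrogen in place of cyano on this aromatic carbon gives a number 0.20 log units higher from compound 1 to compound 3 (within the scatter) in this assay, so this read-out does not separate the two compounds. Within the data shown here, this is the first reading at this position, since the earlier step concerned a fluoro change at a different place. Nothing shown bears on the reason for this result.

Open, as far as these compounds go, is whether an amine or a carboxylic acid on this aromatic carbon would also stay within the scatter of compound 1. Also open, from the compounds shown here alone, is whether the same replacement gives a similar step on the core of compound 2.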